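Phenyl for ethyl beside the carboxylic acid

A few compounds are considered here, and "the series" means these few. Any claim that something is new, unique, unknown or untested is made for them only; others in the source may bear on it.

Compound 1 `CN(C)C(=O)C(C)(C)COc1nnc(-c2ccc(NC(=O)c3ccc4ccccc4c3)cc2)n1C`: in an assay on 3T3-L1 cells for inhibition of diacylglycerol O-acyltransferase 1 (Mus musculus) (on this read-out higher numbers stand for weaker inhibition and lower numbers for stronger inhibition), compound 1 gives 440 nM.
Compound 2 `CCC(Sc1nnc(-c2ccc(NC(=O)c3ccc(Cl)c(Cl)c3)cc2)n1C)C(=O)O`: in this assay compound 2 reaches only the assay limit, > 20000 nM.
Compound 3 `Cn1c(OCC(C)(C)C(N)=O)nnc1-c1ccc(NC(=O)c2ccc3ccccc3c2)cc1`: in this assay compound 3 gives 6100 nM.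

Going by the values given here, the one measured step, a 14-fold higher number from compound 1 to compound 3 (1.14 log units; beyond the scatter), concerns the amide end of the shared core. Compound 2 stands at the limit, with the inhibition too weak to give a number, as the limit of > 20000 nM in this assay, at which 1 of the 3 values shown sits, records. Compound 4 `Cn1c(SC(C(=O)O)c2ccccc2)nnc1-c1ccc(NC(=O)c2ccc(Cl)c(Cl)c2)cc1` differs from compound 2 by phenyl in place of ethyl on a saturated chain carbon bound to a carbonyl carbon and a sulfur. Among the compounds with values here, no measured step touches this part of the molecule, so the step has no precedent here and no direction can be read from the data. Compound 4 is therefore expected to remain at the same limit, and its estimated value is 20000 nM (range 5000 nM to 80000 nM). The expected step is a number no higher from compound 2 to compound 4 (the limit leaves the size open), not beyond the scatter.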

Compound 4, half-maximal inhibitory concentration: > 20000 nM
Compound 4: only a limit was reported; the forecaster's own chance of this, stated with the estimate: 70%; the middle value sits exactly at the limit.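

Compound 2 and compound 4 both stop at the assay limit, so no step can be read between them: the limit of > 20000 nM in this assay, at which 2 of the 4 values shown sit. The compounds shown leave open whether phenyl in place of ethyl changes inhibition at all.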